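A few compounds are considered here, and "the series" means these few. Any claim that something is new, unique, unknown or untested is made for them only; others in the source may bear on it.

Compound 1, `COc1cc(Nc2ncnc3c(NC(=O)Nc4cc(Cl)cc(Cl)c4)cccc23)cc(OC)c1`, gives 30.2 nM in a functional assay on RT-112 cells (Homo sapiens) for antiproliferative activity, read by MTT assay, with a stated time of 72 h; a higher number here means a weaker inhibitor of growth, a lower number a stronger inhibitor of growth.
Compound 2, `COc1cc(Nc2ncnc3c(NC(=O)Nc4ccc([N+](=O)[O-])cc4)cccc23)cc(OC)c1`, gives only a limit of the assay, > 20000 nM, in this assay.

Going by the values given here, compound 1 stands as the only real number among the two values shown; the other value is a limit, (the limit of > 20000 nM in this assay, at which 1 of the 2 values shown sits). Compound 3, `COc1cc(Nc2ncnc3c(NC(=O)Nc4ccc(F)cc4F)cccc23)cc(OC)c1`, has not yet been measured. It differs from compound 1 in one place: 2,4-difluorophenyl in place of 3,5-dichlorophenyl on an amide-type nitrogen. Among the compounds with values here, the only measured step that bears on this change is the swap of the same aryl group, where an at least 660-fold higher number from compound 1 to compound 2 (2.82 log units; beyond the scatter). Within the data shown here, that step replaced 3,5-dichlorophenyl with 4-nitrophenyl, a different kind of change than the present one, so its full size cannot be carried over; it shows only that altering this group can cost a great deal of activity. A smaller but still clear loss is therefore expected for compound 3, with a 9.9-fold higher number from compound 1 to compound 3 (1.00 log units; beyond the scatter). The estimate for compound 3 in this assay is 300 nM, within a range from 40 nM to 5000 nM.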

Compound 3, concentration for 50% growth inhibition: 2460 nM
Beside the measured number, compound 3's estimate is 8.2-fold (0.91 log units) below it; low and high end bracket the measured number.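

In this assay, the group on the amide-type nitrogen proves sensitive even when one dihalogenated phenyl ring replaces another, as 2,4-difluorophenyl in place of 3,5-dichlorophenyl gives an 81-fold higher number from compound 1 to compound 3 (1.91 log units; beyond the scatter). The outcome at this position is also graded rather than all-or-nothing, since 2,4-difluorophenyl in place of 4-nitrophenyl gives an at least 8.1-fold lower number from compound 2 to compound 3 (0.91 log units; beyond the scatter). The value of compound 2 is only a limit of the assay, so this second step is a bound and not an exact size: the limit of > 20000 nM in this assay, at which 1 of the 3 values shown sits.

The halogen and the substitution pattern both differ between compound 1 and compound 3, so the compounds shown cannot tell which of the two goes with the change in activity; 3,5-difluorophenyl and 2,4-dichlorophenyl would separate them. Going by these compounds, whether the aromatic ring is needed at all also stays open, and a cyclohexyl group would test that.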